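A few compounds are considered here, and "the series" means these few. Any claim that something is new, unique, unknown or untested is made for them only; others in the source may bear on it.

Within the data shown here, compound 2 `CC#CC(CC(=O)O)c1ccc(OCc2ccc(C(=O)N3CCN(c4ccc(Cl)cc4)CC3)s2)cc1` is the only compound of the pair with a number in a functional assay on HEK293 cells for agonist activity at Free fatty acid receptor 1 (Homo sapiens), read by fluorescence and calcium flux (a lower number here means that less compound is needed, a higher number that more compound is needed for the effect), where compound 2 gives 133 nM. Compound 1 `CC#CC(CC(=O)O)c1ccc(OCc2ccc(C(=O)N3CCN(C)CC3)s2)cc1` gives only a limit of the assay in this assay, > 5000 nM, and this the limit of > 5000 nM in this assay, at which 1 of the 2 values shown sits, is what the comparison rests on. The step of an at least 37-fold lower number from compound 1 to compound 2 (1.57 log units; beyond the scatter) shows that an aromatic ring on the ring nitrogen matters. Compound 3 `CC#CC(CC(=O)O)c1ccc(OCc2ccc(C(=O)N3CCN(c4ccccc4F)CC3)s2)cc1` keeps such a ring; the change is 2-fluorophenyl in place of 4-chlorophenyl on an amine nitrogen in a ring. Because an at least 37-fold lower number from compound 1 to compound 2 (1.57 log units; beyond the scatter) is the step that put an aromatic ring on the ring nitrogen and compound 3 keeps such a ring, a far smaller shift is expected, perhaps a mild weakening of a 1.9-fold higher number from compound 2 to compound 3 (0.27 log units; within the scatter). Compound 3 is therefore estimated at 250 nM, within 80 nM to 800 nM.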

Compound 3, half-maximal effective concentration: 113 nM
Beside the measured number, compound 3's estimate is 2.2-fold (0.34 log units) above it; low and high end bracket the measured number.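

In this assay, 2-fluorophenyl in place of 4-chlorophenyl gives a 1.2-fold lower number from compound 2 to compound 3 (0.07 log units; within the scatter), so these two groups cannot be told apart here, even though the halogen and its place on the ring both differ. The gain over methyl also holds for the second aromatic group, with an at least 44-fold lower number from compound 1 to compound 3 (1.64 log units; beyond the scatter), so it is not tied to 4-chlorophenyl. That step rests on a limit of the assay for compound 1: the limit of > 5000 nM in this assay, at which 1 of the 3 values shown sits.

As far as these compounds go, whether a halogen is needed at all stays open; an unsubstituted phenyl or a cyclohexyl on that nitrogen would address this. The effects of swapping the halogen and of moving it also remain unseparated.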